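Swapping the aryl group: from thiophene to 4-hydroxyphenyl

The source may report more compounds than this note shows. Statements on the series, on what has been measured and on what is new or still open speak of the compounds shown alone.

Measured compounds in a functional assay on CHO cells for agonist activity at Alpha-2B adrenergic receptor (Homo sapiens); on this read-out lower numbers stand for smaller maximal responses and higher numbers for larger maximal responses:
- compound 1 `CC(Oc1ccccc1-c1ccc([N+](=O)[O-])cc1)C1=NCCN1` gives only a limit, < 0.3.
- compound 2 `Cc1cccc(-c2ccccc2OC(C)C2=NCCN2)c1` gives only a limit, < 0.3.
- compound 3 `CC(Oc1ccccc1-c1cccs1)C1=NCCN1` gives 0.6.

Among the compounds with values here, compound 3 thus holds the only actual number in this assay; the other two values are limits, at which two of the three values sit (the limit of < 0.3 in this assay, at which 2 of the 3 values shown sit). The step from compound 2 to compound 3 was a number at least 0.30 higher from compound 2 to compound 3 (beyond the scatter). Compound 4 `CC(Oc1ccccc1-c1ccc(O)cc1)C1=NCCN1` differs from compound 3 by 4-hydroxyphenyl in place of thiophen-2-yl on an aromatic carbon. That change reverses the direction of the measured step, returning from a five-membered heteroaryl to a six-membered carbon-only ring, as in compound 1 and compound 2, both of which sit at the limit. A downward step is therefore expected in this assay, a number 0.25 lower from compound 3 to compound 4 (beyond the scatter), with a fair chance that only a limit is reported. Compound 4 is estimated at 0.35, in the range 0.2 to 0.55.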

Compound 4, intrinsic activity: the largest response reached, as a fraction of the reference agonist's: < 0.3
Compound 4: no number, only a limit; the forecaster's own chance of this, stated with the estimate: 45%; at least 0.050 between middle value and limit.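

In this assay, 4-hydroxyphenyl in place of thiophen-2-yl gives a number at least 0.30 lower from compound 3 to compound 4 (beyond the scatter), so a ring carrying a hydrogen-bond donor does not keep the response on this aromatic carbon. Thiophen-2-yl is now the only group shown here with an actual number, while the rings bearing nitro, methyl and hydroxy all end at a limit: the limit of < 0.3 in this assay, at which 3 of the 4 values shown sit. The steps from compound 1 and compound 2 to compound 4 cannot be read, as both ends are limits. As far as these compounds go, whether an amine or a carboxylic acid on the six-membered ring would lift the response above that limit stays open, as does whether furan-2-yl would match thiophen-2-yl.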